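Series notes: aryl exchange on an inactive acid

The source may hold more compounds than are shown below. What is called first, only, known or untested is meant among the compounds shown, and "the series" means these compounds.

Two compounds of the series have been run in a functional assay on A549 cells (Homo sapiens) for inhibition, read by MTT assay, with a stated time of 24 h; on this read-out lower numbers stand for stronger inhibition and higher numbers for weaker inhibition. Compound 1 `CCOC(=O)C1=Cc2ccccc2OC1(OCc1cc(-c2ccc(F)cc2F)no1)C(F)(F)F` carries an ethyl ester and a 2,4-difluorophenyl group; in this assay compound 1 returns only a limit, > 150000 nM. Compound 2 `O=C(O)C1=Cc2ccccc2OC1(OCc1cc(-c2ccc3ccccc3c2)no1)C(F)(F)F` carries the free acid and a naphthalen-2-yl group; in this assay compound 2 likewise returns only a limit, > 150000 nM. Compound 2 thus stands at the limit of this assay and no number is known for it; the whole measured set sits there, as summarised by the limit of > 150000 nM in this assay, at which 2 of the 2 values shown sit. Within the data shown here, no step between two measured numbers exists.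

Compound 3 `O=C(O)C1=Cc2ccccc2OC1(OCc1cc(-c2ccc(F)cc2F)no1)C(F)(F)F` is the next compound: relative to compound 2 the change is 2,4-difluorophenyl in place of naphthalen-2-yl on an aromatic carbon. Both groups already occur in the measured set, each on a compound that reaches only the limit. The expected step from compound 2 to compound 3 is none beyond the scatter, a step that the limit leaves unreadable from compound 2 to compound 3. Compound 3 is expected to give about 200000 nM in this assay, within 80000 nM to 600000 nM, and is most likely to be reported again as a limit only.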

Compound 3, half-maximal inhibitory concentration: > 150000 nM
Compound 3 was reported as a limit; the forecaster's own chance of this, stated with the estimate: 85%; the middle value is on the limit's open side.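

Compound 3 returns only a limit in this assay, > 150000 nM. Among these compounds, no step can therefore be read from compound 1 or compound 2 to compound 3, and the whole set stays at a single limit: the limit of > 150000 nM in this assay, at which 3 of the 3 values shown sit. The compounds shown leave open whether any compound of this series gives a measurable number in this assay.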